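This account rests on a few compounds, and the source may have more. Where it says the series, first, only, none or still open, it means among the compounds named here.

Compound 1 `Nc1cc(N)c2nc(-c3ccccc3)c(NCc3ccc(F)cc3)nc2c1` is examined in a functional assay on ACHN cells (Homo sapiens) for inhibition, read by sulforhodamine B assay, with a stated time of 48 h (on this read-out lower numbers stand for stronger inhibition of growth and higher numbers for weaker inhibition of growth), where compound 1 gives 1700 nM. This is the lowest of the two numbers available; its nearest neighbour is compound 2 `COc1ccc(CNc2nc3cc(N)cc(N)c3nc2-c2ccccc2)cc1`, which in this assay gives 14800 nM, and the difference is an 8.7-fold higher number from compound 1 to compound 2 (0.94 log units; beyond the scatter), arising from methoxy in place of fluoro on an aromatic carbon. Compound 3 `Nc1cc(N)c2nc(-c3ccccc3)c(Oc3ccc(F)cc3)nc2c1` has not yet been measured. Relative to compound 1 the change is 4-fluorophenoxy in place of (4-fluorobenzyl)amino on an aromatic carbon. Among the measured compounds shown here, no measured step touches this part of the shared core of compound 1: the only known step, from compound 1 to compound 2, alters the distant methoxy-for-fluoro position and therefore gives no direct guidance on replacing the nitrogen-linked group by an oxygen-linked one. The replacement of the nitrogen-linked group by the oxygen-linked one has no measured counterpart among these compounds. A weakening beyond the scatter seems plausible but uncertain. Compound 3 is therefore expected at 4500 nM, within 1200 nM to 20000 nM, an estimated step of a 2.6-fold higher number from compound 1 to compound 3 (0.42 log units; beyond the scatter).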

Compound 3, concentration for 50% growth inhibition: 13800 nM
For compound 3 the middle estimate is 3.1-fold (0.49 log units) below the measured one; the range from low to high includes it.
By their numbers in this assay, from the lowest: compound 1; then compounds 3 and 2 (each within the scatter of the next).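

The earlier step only exchanged fluoro for methoxy on an aromatic carbon, whereas this one changes the group attached to the shared core on the aromatic carbon next to the ring nitrogen, and it weakens growth inhibition in this assay (an 8.1-fold higher number from compound 1 to compound 3 (0.91 log units; beyond the scatter)). So, for this pair, 4-fluorophenoxy is a clearly poorer replacement for (4-fluorobenzyl)amino at this place, although the entering group has 0 hydrogen-bond donors where the leaving group has 1, and 8 heavy atoms against 9, so several things change at once. Nothing measured here explains the loss.

Which of these differences matters stays open. The 4-fluorobenzyloxy group, or the 4-fluoroanilino group, at this place would help separate the effect of the linking atom from that of the chain length.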